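A few compounds are considered here, and "the series" means these few. Any claim that something is new, unique, unknown or untested is made for them only; others in the source may bear on it.

Compound 1 `Nc1ccccc1NC(=O)c1ccc(CSc2nccc(C(F)(F)F)n2)cc1`, compound 2 `Nc1ccccc1NC(=O)c1ccc(CSc2ccc(Br)cc2)cc1` and compound 3 `Nc1ccccc1NC(=O)c1ccc(CSc2ccc(C(F)(F)F)cn2)cc1` share one core and differ only in the group carried on the far side of the sulfur. In a functional assay on A549 cells (Homo sapiens) for inhibition, read by CCK-8 assay, with a stated time of 72 h, tested at 2 uM (a lower number here means less inhibition of growth, a higher number more inhibition of growth at the concentration tested), compound 1 gives 75.4%, compound 2 gives 33.2%, and compound 3 gives 37.1%. Compound 2 holds the lowest of the three numbers, but compound 3 lies within the usual scatter of it, so the two cannot be told apart; compound 1 stands beyond the scatter above both.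

Compound 4 `Nc1ccccc1NC(=O)c1ccc(CSc2ccc(F)cc2)cc1` has not yet been measured. It differs from compound 2 in one place: fluoro in place of bromo on an aromatic carbon. The ring itself, the sulfur link and the rest of the core stay as they are, and the new group sits on the same aromatic carbon, para to the large group.

Within the data shown here, no pair among the measured compounds shows what a single halogen swap of this kind does; the measured numbers only show that exchanging the whole group beyond the sulfur can move the result. For compound 4 the step from compound 2 is therefore expected to be small, a number 2.2 percentage points lower from compound 2 to compound 4 (within the scatter), and not beyond the scatter in either direction. Compound 4 is thus estimated at 31% in this assay, with a likely range from 16% to 48%.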

Compound 4, percent growth inhibition at one concentration: 43.4%
Compound 4: the middle estimate sits 12.4 percentage points below what was measured; the range from low to high includes it.
By their numbers in this assay, from the lowest: compounds 2, 3 and 4 (each within the scatter of the next, the first and the last beyond it); then compound 1.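

In this assay, among these compounds, the step of a number 10.2 percentage points higher from compound 2 to compound 4 (beyond the scatter) is the first reading of a single change, and it concerns one halogen on the aromatic carbon para to a large group. The step is modest, but it shows that this position is not indifferent: going from 4-bromophenyl to 4-fluorophenyl can move growth inhibition even though one heavy atom simply replaces another and the counted donors, acceptors and charge stay the same. Nothing available accounts for the size or direction of this step, so it stands as an observation without an explanation.

From the compounds shown here alone, with only bromo and fluoro to compare, these two compounds give no trend across substituents, and it remains open what chloro, methoxy, an amine or a carboxylic acid on the same aromatic carbon would do. Going by these compounds, it is also open whether the swap would give a similar step at other concentrations or in other cell lines, as this reading comes from one cell line at one concentration.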